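Fluoro to hydrogen on the aryl ring of compound 1

This account rests on a few compounds, and the source may have more. Where it says the series, first, only, none or still open, it means among the compounds named here.

Compound 1 `Fc1ccc(-c2csc(N/N=C/c3ccc(Cl)cc3Cl)n2)cc1` stands highest of the two numbers in hand. In a functional assay, read by spectrophotometry, with a stated time of 15 min, tested at 80 ug/mL (on this read-out lower numbers stand for a weaker effect and higher numbers for a stronger effect at the one concentration tested), compound 1 gives 94%. Among the measured compounds shown here, the only other measured member, compound 2 `COC(=O)c1cc(-c2csc(N/N=C/c3ccc(Cl)cc3Cl)n2)ccc1OCc1ccccc1`, gives in this assay a value of 71.8%, which lies well below compound 1, beyond the scatter of the read-out; no single-point step between the two is given, so the pair shows only that compound 1 is the higher of the two.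

Compound 3 `Clc1ccc(/C=N/Nc2nc(-c3ccccc3)cs2)c(Cl)c1` is compound 1 with one change: hydrogen in place of fluoro on an aromatic carbon. The fluoro leaves and a hydrogen enters, on an aromatic carbon of a six-membered aromatic ring of carbon only, para to a large group; cut one bond further out, 4-fluorophenyl becomes phenyl. For the measured compounds named here, no measured pair in the set shows this change, so its size is unknown here.

The expectation is a small step, a number 6 percentage points lower from compound 1 to compound 3 (within the scatter), downward if anything, and within the scatter. For compound 3 the estimated value in this assay is 88%, with a range from 70% to 97%.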

Compound 3, a percentage reported as inhibition, at one concentration (the size of the read-out at that concentration, not a potency): 83.1%
For compound 3 the middle estimate is 4.9 percentage points above the measured one, within the range that was stated.
By their numbers in this assay, from the lowest: compound 2; then compound 3; then compound 1.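

Among the compounds shown here, the fluoro on the aromatic carbon, para to a large group, now has a measured step of its own: in this assay the 4-fluorophenyl to phenyl change reads a number 10.9 percentage points lower from compound 1 to compound 3 (beyond the scatter) and so gives this position a size that the earlier pair, with no single-place step, could not give. The number does not collapse with the fluoro gone, since compound 3 still gives 83.1% at the one concentration tested, so a high read-out in this series does not depend on fluoro at this place, although fluoro stands with the higher number of this pair. No measurement in hand bears on why the number moves with this change.

As far as these compounds go, whether this aromatic carbon takes anything other than fluoro or hydrogen stays open: a chloro, a methoxy, an amine or a carboxylic acid here would show whether the number follows the entering group or only the presence of fluoro. From the compounds shown here alone, how the step reads at other concentrations also stays open, as does any single-place link from compound 2 to the other members.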